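The source may report more compounds than this note shows. Statements on the series, on what has been measured and on what is new or still open speak of the compounds shown alone.

Measured compounds:
- Compound 1 `CC(C)(C)c1ccc(Cn2cc(-c3cn([C@H]4C[C@H](O)[C@@H](CO)O4)c(=O)[nH]c3=O)nn2)cc1`: 95%
- Compound 2 `CC(=O)OC[C@H]1O[C@@H](n2cc(-c3cn(Cc4ccc(C(C)(C)C)cc4)nn3)c(=O)[nH]c2=O)C[C@@H]1OC(C)=O`: 106%
- Compound 3 `CC(=O)OC[C@H]1O[C@@H](n2cc(-c3cc(C)no3)c(=O)[nH]c2=O)C[C@@H]1OC(C)=O`: 101%

All three compounds were tested in a functional assay on NCI-H23 cells (Homo sapiens) for cytotoxicity, read by sulforhodamine B assay, tested at 10 uM; a higher number here means more inhibition at the concentration tested (going by the name of the read-out), a lower number less inhibition. Compound 3 sits between the other two: compound 2 is the nearest of the three and compound 1 the furthest, and both gaps are within the usual scatter of this kind of measurement, so on these numbers the three compounds cannot be told apart. All of them inhibit the cells almost completely at the concentration tested.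

Compound 4 `CC(=O)OC[C@H]1O[C@@H](n2cc(-c3cc(-c4ccc(C(C)(C)C)cc4)no3)c(=O)[nH]c2=O)C[C@@H]1OC(C)=O` differs from compound 3 in one place: 4-(tert-butyl)phenyl in place of methyl on an aromatic carbon. The methyl group leaves the aromatic carbon of the five-membered aromatic ring with one nitrogen and one oxygen, and a 4-(tert-butyl)phenyl group enters at the same aromatic carbon.

Within the data shown here, no step between two measured compounds covers this change, so its effect has to be guessed from the compounds at hand. The step expected here is a number 1 percentage points lower from compound 3 to compound 4 (within the scatter), that is, nothing beyond the scatter. This expectation rests on compound 1, which carries a tert-butyl-bearing benzene ring and gives 95%, and on compound 2, which carries the same group and gives 106%. For compound 4 the expected value is 100%, with a range from 85% to 110%.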

Compound 4, a percentage reported as inhibition, at one concentration (the size of the read-out at that concentration, not a potency): 112%
Beside the measured number, compound 4's estimate is 12 percentage points below it; measured number outside the range, above it.
By their numbers in this assay, from the lowest: compounds 1, 3, 2 and 4 (each within the scatter of the next, the first and the last beyond it).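

In this assay, putting 4-(tert-butyl)phenyl in place of methyl on the aromatic carbon next to the ring nitrogen gives a number 11 percentage points higher from compound 3 to compound 4 (beyond the scatter), a modest step. This position therefore accepts a far larger group, with a six-membered aromatic ring in place of a single carbon, and inhibition of the cells does not fall. Nothing available here accounts for the direction of this step.

As far as these compounds go, it remains open whether the step depends on the tert-butyl group or on the benzene ring alone, and a plain phenyl group at the same carbon would separate the two, while an amine, a carboxylic acid or a longer alkyl chain there would show how far other kinds of group are accepted. From the compounds shown here alone, because each number is the size of the read-out at a single concentration, and not a potency, how compound 3 and compound 4 compare at lower concentrations also remains open.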